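Trifluoromethyl for fluoro on a second core

This account rests on a few compounds, and the source may have more. Where it says the series, first, only, none or still open, it means among the compounds named here.

Measured so far:
compound 1, `CC(C)(C)c1ccc(C(CC(=O)O)NS(=O)(=O)c2ccc(F)cc2)cc1`: 66200 nM
compound 2, `CC(C)(C)c1ccc(C(CC(=O)O)NS(=O)(=O)c2ccc(C(F)(F)F)cc2)cc1`: 53700 nM
compound 3, `O=C(O)CC(NC(=O)c1ccc(F)cc1)c1ccccc1F`: 72300 nM

Compound 1 and compound 2 share one core; compound 3 has another, and the difference between the two cores is not broken down here. In a functional assay on MDA-MB-231 cells (Homo sapiens) for antiproliferative activity, read by MTT assay, with a stated time of 24 h (a lower number here means a stronger inhibitor, a higher number a weaker inhibitor), compound 1 gives 66200 nM and compound 2 gives 53700 nM. The step of a 1.2-fold lower number from compound 1 to compound 2 (0.09 log units; within the scatter) comes from trifluoromethyl in place of fluoro on an aromatic carbon. On the other core, compound 3 gives 72300 nM.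

Compound 4, `O=C(O)CC(NC(=O)c1ccc(C(F)(F)F)cc1)c1ccccc1F`, is compound 3 with trifluoromethyl in place of fluoro on an aromatic carbon, the same change at the same kind of place. Because the earlier step of a 1.2-fold lower number from compound 1 to compound 2 (0.09 log units; within the scatter) stayed within the scatter, compound 4 is expected to show a step of a 1.2-fold lower number from compound 3 to compound 4 (0.08 log units; within the scatter). Compound 4 is estimated at 60000 nM, with a range from 30000 nM to 120000 nM.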

Compound 4, half-maximal inhibitory concentration: 59200 nM
Compound 4: middle estimate off by 1.0-fold (0.01 log units), on the high side; low and high end bracket the measured number.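

In this assay trifluoromethyl in place of fluoro on an aromatic carbon gives a 1.2-fold lower number from compound 3 to compound 4 (0.09 log units; within the scatter). Set beside the earlier step, the change reads alike on both cores: the same change on two cores in this assay, a 1.2-fold lower number (0.09 log units; within the scatter) from compound 1 to compound 2 and a 1.2-fold lower number (0.09 log units; within the scatter) from compound 3 to compound 4, 1.0-fold (0.00 log units) apart, within the scatter of two such steps. This shows that the step carried over from one core to the other within the scatter, but since both steps themselves lie within the scatter, it does not show that the change has a real effect on the number, and two pairs say nothing about other cores in the series.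

The compounds shown leave open whether another group at this place, such as an amine, a nitrile or a methoxy group, would move the number beyond the scatter. They also leave open whether a carboxylic acid replacement elsewhere would do so.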